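A few compounds are considered here, and "the series" means these few. Any claim that something is new, unique, unknown or untested is made for them only; others in the source may bear on it.

Measured so far:
compound 1 `C[C@@H]1C[C@@](O)(CC(=O)O)c2cc(Cl)ccc2O1` — 14.9 mg/kg
compound 2 `C[C@@H]1C[C@@](O)(CC(=O)O)c2cc([N+](=O)[O-])ccc2O1` — 12 mg/kg
compound 3 `C[C@@H]1C[C@@](O)(CC(=O)O)c2cc(Cl)cc(Cl)c2O1` — 26.6 mg/kg

All three values come from a functional assay on the whole organism (Sciatic nerve) for inhibition, with Rattus norvegicus as the target, with a stated time of 27 h; on this read-out higher numbers stand for an effect only at larger amounts of compound and lower numbers for an effect already at smaller amounts. Compound 2 differs from compound 1 by nitro in place of chloro on an aromatic carbon, and the step of a 1.2-fold lower number from compound 1 to compound 2 (0.09 log units; within the scatter) is within the scatter. Compound 3 differs from compound 1 by chloro in place of hydrogen on an aromatic carbon, giving a 1.8-fold higher number from compound 1 to compound 3 (0.25 log units; within the scatter).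

Compound 4 `C[C@@H]1C[C@@](O)(CC(=O)O)c2cc([N+](=O)[O-])c(Cl)cc2O1` is not yet measured. It differs from compound 2 by chloro in place of hydrogen on an aromatic carbon. Going by the values given here, this is the same kind of change as the one from compound 1 to compound 3, but the surroundings of the place differ: in compound 3 the entering chloro is ortho to a fused ring and meta to a chloro group, whereas in compound 4 it is ortho to a nitro group and para to a fused ring.

For compound 4 in this assay a step of about a 1.6-fold higher number from compound 2 to compound 4 (0.20 log units; within the scatter) is expected, resting on the step of a 1.8-fold higher number from compound 1 to compound 3 (0.25 log units; within the scatter) seen for compound 3. The estimate for compound 4 is therefore 19 mg/kg, with a range from 10 mg/kg to 36 mg/kg.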

Compound 4, dose for half-maximal effect: 14.9 mg/kg
Beside the measured number, compound 4's estimate is 1.3-fold (0.11 log units) above it, and the stated range covers the measured number.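

Chloro in place of hydrogen on an aromatic carbon of the core of compound 2 gives, in this assay, a 1.2-fold higher number from compound 2 to compound 4 (0.09 log units; within the scatter). Set beside the same change on the core of compound 1, the new step does not differ from the earlier one: the same change on two cores in this assay, a 1.8-fold higher number (0.25 log units; within the scatter) from compound 1 to compound 3 and a 1.2-fold higher number (0.09 log units; within the scatter) from compound 2 to compound 4, 1.4-fold (0.16 log units) apart, within the scatter of two such steps So across these two pairs the change carries from one core to the other without a detectable difference, but both steps lie within the scatter, the chloro enters at different places, and two pairs do not establish a rule for other cores.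

The compounds shown leave open whether an amine or a trifluoromethyl group on the same aromatic carbon would give a step beyond the scatter.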